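Two Low Inhibition Numbers in a Cell Assay and a Dichlorophenyl Carbamate Analogue

The compounds below may be only part of what the source reports. "The series", "measured", "known", "first", "only" and "open" are said of these compounds alone.

Measured so far:
compound 1 `CC(C)=CCC/C(C)=C/CC1Cc2c(OCCCOc3ccc(Cl)cc3)cc(=O)n(CCCO)c2CC1(C)C` gives 0%
compound 2 `CC(C)=CCC/C(C)=C/CC1Cc2c(OC(=O)Nc3cccc(C(F)(F)F)c3)cc(=O)n(CCCO)c2CC1(C)C` gives 6.7%

Both numbers come from a functional assay on PANC-1 cells (Homo sapiens) for inhibition, read by MTT assay, with a stated time of 24 h, tested at 10 uM; a lower number here means less inhibition, a higher number more inhibition at the concentration tested (going by the name of the read-out). On this read-out compound 1 gives 0%, and compound 2 gives 6.7%, the higher of the two numbers, but the gap between them lies within the usual scatter, so the two compounds cannot be told apart on these data. For the measured compounds named here, no pair of measured compounds differing in one place is available, so nothing is known yet about what any single structural change does here.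

Compound 3 `CC(C)=CCC/C(C)=C/CC1Cc2c(OC(=O)Nc3ccc(Cl)c(Cl)c3)cc(=O)n(CCCO)c2CC1(C)C` keeps the shared core of compound 2 and differs in one place: 3,4-dichlorophenyl in place of 3-(trifluoromethyl)phenyl on an amide-type nitrogen. Going by the values given here, with no measured step to lean on and both known values close to zero, the step is expected to be small, a number 1.3 percentage points higher from compound 2 to compound 3 (within the scatter), with no direction beyond the scatter. Compound 3 is therefore expected to give about 8% in this assay, with a likely range from 0% to 25%.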

Compound 3, a percentage reported as inhibition, at one concentration (the size of the read-out at that concentration, not a potency): 0%
The estimate for compound 3 lay 8 percentage points above the measured number, within the range that was stated.
By their numbers in this assay, from the lowest: compounds 1, 3 and 2 (each within the scatter of the next).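

In this assay, placing 3,4-dichlorophenyl instead of 3-(trifluoromethyl)phenyl on the amide-type nitrogen gives a number 6.7 percentage points lower from compound 2 to compound 3 (within the scatter), so this exchange of one ring for another does not shift the read-out measurably. Placing (3,4-dichlorophenyl)carbamoyl instead of 3-(4-chlorophenoxy)propyl on the oxygen on the aromatic ring gives no change at the digits printed from compound 1 to compound 3 (within the scatter), so two quite different groups at that oxygen cannot be told apart here either. Nothing is available that would explain why the numbers stay together.

Still open, going by these compounds, is whether any group at these two places can raise the read-out beyond the scatter. A phenyl ring bearing an amine or a carboxylic acid on the amide-type nitrogen, for example, might or might not behave like the two rings seen so far.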